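The compounds below may be only part of what the source reports. "The series", "measured", "known", "first", "only" and "open" are said of these compounds alone.

Compound 3 `CC1CCN(C2CCN(S(=O)(=O)c3cccnc3)CC2)CC1` carries a pyridin-3-yl group on the sulfonyl sulfur of a core that it shares with compound 2 `CC1CCN(C2CCN(S(=O)(=O)c3ccc(C#N)cc3)CC2)CC1` and compound 1 `Cc1noc(C)c1S(=O)(=O)N1CCC(N2CCC(C)CC2)CC1`. In a functional assay on DLD-1 cells (Homo sapiens) for antiproliferative activity, read by CellTiter-Glo, with a stated time of 72 h (on this read-out higher numbers stand for weaker inhibition and lower numbers for stronger inhibition), compound 3 gives 2400 nM. In this assay compound 2 gives 2800 nM, and the two values sit within the scatter of each other, as the step of a 1.2-fold lower number from compound 2 to compound 3 (0.07 log units; within the scatter) shows. For compound 1 this assay reports only a limit, > 5000 nM. Against that limit the steps of an at least 1.7-fold lower number from compound 1 to compound 2 (0.25 log units; that floor lies within the scatter) and an at least 2.0-fold lower number from compound 1 to compound 3 (0.31 log units; beyond the scatter) are known only as floors, the second of them at least modest, a reading that rests on (the limit of > 5000 nM in this assay, at which 1 of the 3 values shown sits).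

Compound 4 `CC1CCN(C2CCN(S(=O)(=O)c3cccc(N)c3)CC2)CC1` differs from compound 3 in one place: 3-aminophenyl in place of pyridin-3-yl on a sulfonyl sulfur. The measured steps that bear on this change are the three swaps of the group on the sulfonyl sulfur already described; among the two compounds with numbers, the swap between a 4-cyanophenyl and a pyridin-3-yl group moved the value only within the scatter. On that basis the author expects no step beyond the scatter in this assay, the expected step from compound 3 to compound 4 being a 1.0-fold higher number from compound 3 to compound 4 (0.02 log units; within the scatter). For compound 4 the estimate in this assay is therefore 2500 nM, with a range from 1000 nM to 7000 nM.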

Compound 4, half-maximal inhibitory concentration: 3400 nM
Compound 4: middle estimate off by 1.4-fold (0.13 log units), on the low side, within the range that was stated.
By their numbers in this assay, from the lowest: compounds 3, 2 and 4 (each within the scatter of the next). At a limit, above all of these: compound 1.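

Replacing pyridin-3-yl with 3-aminophenyl on the sulfonyl sulfur brings in a carbon-only aromatic ring and a hydrogen-bond donor, yet this assay gives a 1.4-fold higher number from compound 3 to compound 4 (0.15 log units; within the scatter), and the swap from 4-cyanophenyl gives a 1.2-fold higher number from compound 2 to compound 4 (0.08 log units; within the scatter). With this third numbered group, the values for pyridin-3-yl, 4-cyanophenyl and 3-aminophenyl all lie within the scatter of one another, so these compounds set no order among the three groups at this place. The 3,5-dimethyl-1,2-oxazol-4-yl group remains known only through a limit, and its step to 3-aminophenyl is a floor within the scatter, an at least 1.4-fold lower number from compound 1 to compound 4 (0.16 log units; that floor lies within the scatter), which does not separate these two groups, a reading that rests on: the limit of > 5000 nM in this assay, at which 1 of the 4 values shown sits.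

The compounds shown leave open whether a group of another kind on the sulfonyl sulfur, such as a straight alkyl chain, a benzyl group or a phenyl ring carrying a carboxylic acid, would move the value beyond the scatter. They also leave open how much of the activity depends on the rest of the shared core, which stays the same in all of them.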